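The compounds below may be only part of what the source reports. "The series", "measured", "known", "first", "only" and "open" are said of these compounds alone.

Measured compounds:
compound 1 `Cc1oc(C(=O)O)cc1COc1ccc(-c2ccc(CO)cc2)cc1`, 3000 nM
compound 2 `CCCS(=O)(=O)NC(=O)c1cc(COc2ccc(-c3ccc(OC)cc3)cc2)c(C)o1`, 5 nM
compound 3 `CC(=O)c1ccc(-c2ccc(OCc3cc(C(=O)NS(=O)(=O)c4ccccc4)oc3C)cc2)cc1`, 20 nM

All three numbers come from an assay on cells for displacement of a labelled ligand from prostaglandin E2 receptor EP4 subtype (Homo sapiens), read by scintillation counting; on this read-out lower numbers stand for stronger inhibition and higher numbers for weaker inhibition. Compound 2 gives the lowest number of the three; the nearest is compound 3, whose gap to compound 2 lies beyond the scatter, and the furthest is compound 1, whose gap is far beyond it. For the measured compounds named here, compound 1 carries a free carboxylic acid and a hydroxymethyl on the shared core, whereas compound 2 and compound 3 both carry an acylsulfonamide; no step between compounds differing in one place is available, so those two gaps are read only as what the values show.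

Compound 4 `COc1ccc(-c2ccc(OCc3cc(C(=O)NS(=O)(=O)Cc4ccccc4)oc3C)cc2)cc1` is not yet measured. It keeps the methoxy-substituted biphenyl ether of compound 2 and changes only the sulfonyl substituent: phenyl in place of ethyl on a saturated chain carbon bound to a sulfonyl sulfur. Compound 3 shows that an aromatic ring on the sulfonyl sulfur is tolerated in this assay, but it also differs at the biphenyl end, so it gives no clean reading of the sulfonyl change alone. The expected step from compound 2 to compound 4 in this assay is a 1.6-fold higher number from compound 2 to compound 4 (0.20 log units; within the scatter), small and toward a somewhat higher number, though possibly within the scatter. For compound 4 the estimated value in this assay is 8 nM, in the range 3 nM to 25 nM.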

Compound 4, inhibition constant: 3 nM
Beside the measured number, compound 4's estimate is 2.7-fold (0.43 log units) above it, within the range that was stated.
By their numbers in this assay, from the lowest: compounds 4 and 2 (each within the scatter of the next); then compound 3; then compound 1.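

In this assay the change reads a 1.7-fold lower number from compound 2 to compound 4 (0.22 log units; within the scatter) and so gives no separation between the propylsulfonyl and benzylsulfonyl forms of the acylsulfonamide. For the compounds shown here, this is the first pair that differs in one place, and it shows that the saturated chain carbon bound to a sulfonyl sulfur can carry phenyl, with 6 heavy atoms and an aromatic ring, in place of ethyl, with 2 heavy atoms, without a shift beyond the scatter. Nothing available bears on why the two values stay so close.

Still open, on these data alone, is how far this tolerance extends: a longer chain between the sulfonyl sulfur and the phenyl, or an amine or a nitrile on that phenyl, could behave differently from the unsubstituted benzyl group. The shown compounds also leave open whether the same equivalence of ethyl and phenyl at this place would hold with the acetyl group of compound 3 in place of the methoxy group of compound 2, since this single pair carries the methoxy group on both sides.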